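The compounds below may be only part of what the source reports. "The series", "measured", "known", "first", "only" and "open" are said of these compounds alone.

Measured compounds in this set:
compound 1, `Cc1ccc(S(=O)(=O)NCc2ccc(CNC(=O)c3ccccc3)cc2)cc1`, > 1000 nM in an assay on MDA-MB-231 cells for binding affinity to C-X-C chemokine receptor type 4 (Homo sapiens), read by immunofluorescence and microscopy, with stated times of 10 min and 30 min; on this read-out lower numbers stand for an effect already at smaller amounts and higher numbers for an effect only at larger amounts of compound
compound 2, `O=C(NCc1ccc(CNS(=O)(=O)c2ccccc2)cc1)c1cccnc1`, 10 nM in this assay

The value of compound 1 is a limit of this assay, not a number; it is the limit noted at the limit of > 1000 nM in this assay, at which 1 of the 2 values shown sits. Among the compounds with values here, compound 2 is the only compound of the two that gives a number in this assay, and the other value shown beside it is a limit, so no measured step between the two can be stated.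

Compound 3, `O=C(NCc1ccc(CNS(=O)(=O)c2ccccc2)cc1)c1c(Cl)cc(Cl)cc1Cl`, is not yet measured. It differs from compound 2 in one place: 2,4,6-trichlorophenyl in place of pyridin-3-yl on a carbonyl carbon. Within the data shown here, compound 2, with pyridin-3-yl on the carbonyl carbon, is the one that gives a number; compound 1, with phenyl there and a further change at the sulfonyl end, is the one at the limit. Among the measured compounds shown here, on that basis the step from compound 2 to compound 3 is expected to go toward weaker binding, beyond the scatter, though this rests on two compounds only and no pair differing in one place. The expected step is a 30-fold higher number from compound 2 to compound 3 (1.48 log units; beyond the scatter). Compound 3 is estimated at 300 nM, between 50 nM and 3000 nM.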

Compound 3, effective concentration (reported as EC, without a stated level of effect): 10 nM
For compound 3 the middle estimate is 30-fold (1.48 log units) above the measured one; measured number outside the range, below it.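

In this assay, within the data shown here, the exchange of pyridin-3-yl for 2,4,6-trichlorophenyl on the carbonyl carbon gives no change at the digits printed from compound 2 to compound 3 (within the scatter), the first step that can be read. For this pair, the ring nitrogen and its hydrogen-bond acceptor are therefore not needed at this place to keep a number in the nanomolar range, and a ring of carbon only, carrying three chlorines and more heavy atoms, reads the same. The data shown include no measured property that bears on why two such different groups read alike.

Going by these compounds, compound 1 gives only a limit of the assay and differs from compound 2 and compound 3 in more than one place, so its steps to them cannot be read, and the effect of a plain phenyl on the carbonyl carbon with the sulfonyl end of compound 2 kept stays open. Also open is how a group such as a piperidin-4-yl amine or a carboxylic acid-bearing phenyl would read on the same carbonyl carbon in this assay, since both groups shown here are six-membered aromatic rings with no net charge.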